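Swapping an Aromatic Substituent: Nitro Replaces Dimethylamino

The source may report more compounds than this note shows. Statements on the series, on what has been measured and on what is new or still open speak of the compounds shown alone.

Measured compounds:
compound 1 `Cc1ccc(S(=O)(=O)NC(=O)/C=C/c2ccc(Cl)cc2)cc1` 4.6 ug/mL
compound 2 `Cc1ccc(S(=O)(=O)NC(=O)/C=C/c2ccc(N(C)C)cc2)cc1` 4.3 ug/mL

In a functional assay on B16-F10 cells (Mus musculus) for antiproliferative activity, read by ELISA and MTT assay, with a stated time of 48 h (on this read-out higher numbers stand for weaker inhibition and lower numbers for stronger inhibition), compound 2 gives the lowest of the two numbers, though compound 1 sits close by: a 1.1-fold lower number from compound 1 to compound 2 (0.03 log units; within the scatter). Compound 3 `Cc1ccc(S(=O)(=O)NC(=O)/C=C/c2ccc([N+](=O)[O-])cc2)cc1` is not yet measured; it differs from compound 2 by nitro in place of dimethylamino on an aromatic carbon. Among the measured compounds shown here, the only measured step, from compound 1 to compound 2, changed the same aromatic carbon and stayed within the scatter, so no shift beyond the scatter is expected for compound 3 in this assay, with a 1.0-fold higher number from compound 2 to compound 3 (0.02 log units; within the scatter) as the estimated step. Compound 3 is therefore expected near 4.5 ug/mL, between 2.5 ug/mL and 8 ug/mL.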

Compound 3, half-maximal inhibitory concentration: 13.5 ug/mL
For compound 3 the middle estimate is 3.0-fold (0.48 log units) below the measured one; the measured number lies above the stated range.
By their numbers in this assay, from the lowest: compounds 2 and 1 (each within the scatter of the next); then compound 3.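

In this assay the aromatic carbon para to a large group proves sensitive to its substituent, which the earlier pair, compound 1 and compound 2, lying within the scatter of each other, did not reveal. Nitro brings weaker inhibition in both comparisons, with a 3.1-fold higher number from compound 2 to compound 3 (0.50 log units; beyond the scatter) and a 2.9-fold higher number from compound 1 to compound 3 (0.47 log units; beyond the scatter). Nothing available explains this shift.

On these data alone, whether a primary amine, a methoxy group or a carboxylic acid on this carbon would behave like nitro or like chloro and dimethylamino remains open. So does the effect of nitro on other ring carbons.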